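This account rests on a few compounds, and the source may have more. Where it says the series, first, only, none or still open, it means among the compounds named here.

Measured compounds:
Compound 1, `COc1cc(-n2cnc3ccc(-c4ccccc4Cl)cc32)cc(OC)c1OC` — in a functional assay on A549 cells (Homo sapiens) for antiproliferative activity, read by MTT assay, with a stated time of 72 h (on this read-out higher numbers stand for weaker inhibition and lower numbers for stronger inhibition), compound 1 gives > 10000 nM.
Compound 2, `COc1cc(-n2cnc3ccc(-c4ccc(C(C)=O)cc4)cc32)cc(OC)c1OC` — in this assay compound 2 gives 2510 nM.

The value of compound 1 is a limit of this assay, not a number; compound 1 sits at the limit of > 10000 nM in this assay, at which 1 of the 2 values shown sits, and only a range is known for it. Compound 3, `COc1cc(-n2cnc3ccc(-c4ccc([N+](=O)[O-])cc4)cc32)cc(OC)c1OC`, is not yet measured. It differs from compound 1 by 4-nitrophenyl in place of 2-chlorophenyl on an aromatic carbon.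

Within the data shown here, one measured step bears on this change. Replacing the same 2-chlorophenyl of compound 1 with 4-acetylphenyl gave an at least 3.9-fold lower number from compound 1 to compound 2 (0.60 log units; beyond the scatter), a step out of the limit into a measurable number. Among the measured compounds shown here, compound 3 carries a different group at the same place, 4-nitrophenyl, and no measured pair shows the nitrophenyl against the acetylphenyl, so only the direction of the one known step is available as a guide. A step of similar size, toward a lower number, is therefore expected.

The expected step is an at least 3.1-fold lower number from compound 1 to compound 3 (0.49 log units; beyond the scatter). Compound 3 is estimated at 3200 nM, with a range from 1000 nM to 10000 nM.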

Compound 3, half-maximal inhibitory concentration: 8940 nM
Compound 3: middle estimate off by 2.8-fold (0.45 log units), on the low side; measured number inside the range.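

In this assay, among these compounds, the gain seen with 4-acetylphenyl does not carry over to every 4-substituted phenyl at this aromatic carbon: nitro in place of acetyl gives a 3.6-fold higher number from compound 2 to compound 3 (0.55 log units; beyond the scatter), so the identity of the group on the phenyl ring matters here, and compound 2 remains the only compound of the three with a value clearly inside the measurable range. Measured against the 2-chlorophenyl, the change gives an at least 1.1-fold lower number from compound 1 to compound 3 (0.04 log units; that floor lies within the scatter), and since that floor lies within the scatter, compound 3 cannot be said to differ from compound 1. Compound 1 stands at a limit of the assay, not at a number: the limit of > 10000 nM in this assay, at which 1 of the 3 values shown sits.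

Compound 1 carries its chlorine in the 2-position, whereas compound 2 and compound 3 carry their groups in the 4-position, so the shown compounds do not separate the place of the substituent from its identity, a question that a 4-chlorophenyl at this carbon would address. Also open, on these data alone, is whether the acetyl carbonyl itself is what sets compound 2 apart, which a 4-aminophenyl, a 4-carboxyphenyl or a phenyl bearing a longer ketone chain at the same carbon would help to test.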